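The source may hold more compounds than are shown below. What is called first, only, known or untested is meant among the compounds shown, and "the series" means these compounds.

Of the compounds shown here, two have been measured in an assay on isolated protein for inhibition of Rho-associated protein kinase 2 (Homo sapiens), read by radiometric assay; a lower number here means a stronger inhibitor, a higher number a weaker inhibitor. Compound 1 `NCc1ccc(C(=O)Nc2ccncc2)cc1-c1cccc(C(=O)OCC2CCCCC2)c1` gives 48 nM, while compound 2 `NCc1ccc(C(=O)Nc2ccncc2F)cc1-c1cccc(C(=O)OCC2CC2)c1` gives 2.7 nM. Compound 2 thus holds the lower of the two numbers, and the gap to compound 1 lies beyond the usual scatter of repeated measurements. The two compounds differ in more than one place, so the difference in their numbers cannot be tied to any single part of the structure.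

Compound 3 `COC(=O)c1cccc(-c2cc(C(=O)Nc3ccncc3F)ccc2CN)c1` has not yet been measured in this assay. It differs from compound 2 in one place only: hydrogen in place of cyclopropyl on a saturated chain carbon bound to an oxygen next to a carbonyl group. Put simply, the cyclopropylmethyl ester of compound 2 becomes a methyl ester in compound 3, and the rest of the molecule stays as it is.

For the measured compounds named here, no measured pair shows this exact change, so the step can only be guessed. The expected step from compound 2 to compound 3, a 1.9-fold higher number from compound 2 to compound 3 (0.27 log units; within the scatter), is a modest weakening, not far outside the scatter. Compound 3 is therefore estimated at 5 nM, within a range from 1.5 nM to 15 nM.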

Compound 3, half-maximal inhibitory concentration: 7.8 nM
The estimate for compound 3 lay 1.6-fold (0.19 log units) below the measured number, within the range that was stated.
By their numbers in this assay, from the lowest: compound 2; then compound 3; then compound 1.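

For the compounds shown here, this is the first pair in this assay that differs in one place only, so a change in the number can now be tied to a single part of the structure: replacing the cyclopropylmethyl ester with a methyl ester gives a 2.9-fold higher number from compound 2 to compound 3 (0.46 log units; beyond the scatter) and leaves the rest of the molecule untouched. The step is modest but beyond the scatter, so the cyclopropyl does count at this position, yet compound 3 still gives 7.8 nM with only a hydrogen in its place, which shows that a low number here does not depend on keeping that three-membered ring. Nothing at hand bears on what lies behind this step.

A single pair cannot show whether the ring itself matters or whether any larger group on this ester would do the same, and an ethyl ester, a longer chain such as a butyl ester, or an open branched group such as isobutyl would help to separate these readings. On these data alone, whether the ester can be replaced altogether, for instance by a carboxylic acid or an amide, also stays open.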